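Replacing a Dihydroxyphenyl Ring with a Quinone Ring

The source may report more compounds than this note shows. Statements on the series, on what has been measured and on what is new or still open speak of the compounds shown alone.

Measured compounds:
compound 1 `COc1ccc(OC)c(-c2cc(-c3ccccc3)nn2-c2ccc(S(=O)(=O)NC(C)=O)cc2)c1` — 37700 nM
compound 2 `CC(=O)NS(=O)(=O)c1ccc(-n2nc(-c3ccccc3)cc2-c2cc(O)ccc2O)cc1` — 100000 nM

In a functional assay on cells (Cancer cell lines, Homo sapiens) for cytotoxicity, read by sulforhodamine B assay, with a stated time of 48 h (on this read-out lower numbers stand for stronger inhibition of growth and higher numbers for weaker inhibition of growth), compound 2 gives 100000 nM, the highest of the two numbers; its nearest neighbour is compound 1, which in this assay gives 37700 nM. For the measured compounds named here, the only measured step, a 2.7-fold higher number from compound 1 to compound 2 (0.42 log units; beyond the scatter), put a 2,5-dihydroxyphenyl in place of a 2,5-dimethoxyphenyl on an aromatic carbon of the shared core and raised the number modestly.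

Compound 3 `CC(=O)NS(=O)(=O)c1ccc(-n2nc(-c3ccccc3)cc2C2=CC(=O)C=CC2=O)cc1` carries the change a group of 8 heavy atoms (6 carbon, 2 oxygen; one six-membered non-aromatic ring of carbon only) in place of a group of 8 heavy atoms (6 carbon, 2 oxygen; one six-membered aromatic ring of carbon only), on an aromatic carbon: a group of 8 heavy atoms with one six-membered non-aromatic ring of carbon only, 4 double bonds outside aromatic rings and 0 hydrogen-bond donors enters where the 2,5-dihydroxyphenyl left. Going by the values given here, no measured step involves such a ring, so the direction is uncertain; the one step available is modest, and a step of similar or smaller size in either direction in this assay is expected. The estimated change is a 1.7-fold lower number from compound 2 to compound 3 (0.22 log units; within the scatter), and compound 3 is expected to give about 60000 nM, within the range 15000 nM to 150000 nM.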

Compound 3, concentration for total growth inhibition: 100000 nM
Compound 3: the middle estimate sits 1.7-fold (0.22 log units) below what was measured; the measured number falls inside the stated range.
By their numbers in this assay, from the lowest: compound 1; then compounds 2 and 3 (each within the scatter of the next).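

At this aromatic carbon of the shared core, in this assay, replacing the 2,5-dihydroxyphenyl with the six-membered non-aromatic ring gives no change at the digits printed from compound 2 to compound 3 (within the scatter). This position therefore shows no measurable difference between an aromatic ring with hydrogen-bond donors and a non-aromatic ring without them. Measured against the 2,5-dimethoxyphenyl, the new ring gives a 2.7-fold higher number from compound 1 to compound 3 (0.42 log units; beyond the scatter), so compound 1 keeps the lowest number of the three, and both groups without the methyl caps read alike.

Nothing measured on these compounds points to a cause for this result. On these data alone, it remains open whether an amine, a carboxylic acid or a plain phenyl at this carbon would bring the number below that of compound 1.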